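From compound 2 to compound 3 in a deacetylase series

The source may report more compounds than this note shows. Statements on the series, on what has been measured and on what is new or still open speak of the compounds shown alone.

Compound 1 `Cn1c(Sc2c(F)cc(C(=O)NO)cc2F)nnc1-c1ncccc1F` and compound 2 `O=C(NO)c1ccc(Cn2nnc(-c3ccccn3)n2)cc1` were both measured in an assay on Sf9 cells for inhibition of protein deacetylase HDAC6 (Homo sapiens), read by fluorescence; on this read-out higher numbers stand for weaker inhibition and lower numbers for stronger inhibition. In this assay compound 1 gives 6 nM. In this assay compound 2 gives 9 nM, the higher of the two numbers, though the gap to compound 1 lies within the scatter. Compound 3 `Nc1ccc(-c2nnn(Cc3ccc(C(=O)NO)cc3)n2)cc1` has not yet been measured; it differs from compound 2 by 4-aminophenyl in place of pyridin-2-yl on an aromatic carbon. Among the compounds with values here, no step between measured compounds is available to guide this change. Compound 3 is therefore expected to give about 15 nM, with a range from 5 nM to 50 nM. The expected step of a 1.7-fold higher number from compound 2 to compound 3 (0.22 log units; within the scatter) is a small weakening, hardly beyond the scatter.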

Compound 3, half-maximal inhibitory concentration: 1 nM
Estimate against measurement, compound 3: 15-fold (1.18 log units) above; measured number below the stated range.
By their numbers in this assay, from the lowest: compound 3; then compounds 1 and 2 (each within the scatter of the next).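

In this assay, the group on this aromatic carbon of the five-membered aromatic ring with 4 nitrogen clearly matters: 4-aminophenyl in place of pyridin-2-yl gives a 9.0-fold lower number from compound 2 to compound 3 (0.95 log units; beyond the scatter). Compounds 1 and 2 differ in more than one place, so they could not isolate this position. Nothing measured here bears on the reason for the step. Going by these compounds, whether the step follows the amine or the carbon-only ring remains open, as both change together. A plain phenyl group or a 4-hydroxyphenyl group on the same carbon would separate the two.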